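A few compounds are considered here, and "the series" means these few. Any claim that something is new, unique, unknown or untested is made for them only; others in the source may bear on it.

Measured compounds in a functional assay on FaDu cells (Homo sapiens) for cytotoxicity, read by MTT assay, with a stated time of 72 h; on this read-out higher numbers stand for lower toxicity in this test and lower numbers for higher toxicity in this test:
- compound 1 `COc1ccc(NC(=O)C(=O)c2cn(C(C)C)c3ccccc23)cn1`: compound 1 gives 85 nM
- compound 2 `COC(=O)CCn1cc(C(=O)C(=O)Nc2ccc(OC)nc2)c2ccccc21`: compound 2 gives 168 nM
- compound 3 `CCC(C)n1cc(C(=O)C(=O)Nc2ccc(OC)nc2)c2ccccc21`: compound 3 gives 68 nM

Compound 3 is set apart from compound 2 by a 2.5-fold lower number from compound 2 to compound 3 (0.39 log units; beyond the scatter), beyond the scatter, whereas against compound 1 the step of a 1.3-fold lower number from compound 1 to compound 3 (0.10 log units; within the scatter) lies within the scatter, so compounds 1 and 3 are not distinguished on these numbers.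

Compound 4 `COc1ccc(NC(=O)C(=O)c2cn(CCOC(C)C)c3ccccc23)cn1` differs from compound 3 only on the aromatic nitrogen: 2-isopropoxyethyl in place of sec-butyl on an aromatic nitrogen.

For the measured compounds named here, two measured steps bear on this. Compound 1 to compound 2 placed an oxygen-bearing chain on the same nitrogen and gave a 2.0-fold higher number from compound 1 to compound 2 (0.30 log units; within the scatter); compound 2 to compound 3 removed it in favour of sec-butyl and gave a 2.5-fold lower number from compound 2 to compound 3 (0.39 log units; beyond the scatter). Both point the same way: an oxygen-bearing chain on this nitrogen went with a higher number, modest at most. Going by the values given here, the chain in compound 4 carries an ether rather than an ester, and no measured pair tests that, so the expectation is a small step upward, a 1.6-fold higher number from compound 3 to compound 4 (0.21 log units; within the scatter), near the edge of the scatter.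

Compound 4 is estimated at 110 nM, with a range of 55 nM to 220 nM.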

Compound 4, concentration lethal to 50% of the cells: 211 nM
Compound 4: the middle estimate sits 1.9-fold (0.28 log units) below what was measured; measured number inside the range.
By their numbers in this assay, from the lowest: compounds 3, 1, 2 and 4 (each within the scatter of the next, the first and the last beyond it).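

In this assay the 2-isopropoxyethyl chain on the aromatic nitrogen now separates clearly from both branched alkyl groups, with a 3.1-fold higher number from compound 3 to compound 4 (0.49 log units; beyond the scatter) against sec-butyl and a 2.5-fold higher number from compound 1 to compound 4 (0.39 log units; beyond the scatter) against isopropyl. The earlier link between an oxygen-bearing chain and a higher number therefore holds for an ether as well as for an ester, and both compounds 2 and 4 go with it, while compounds 1 and 3 stay together at the low end. The two oxygen-bearing chains are not distinguished, since a 1.3-fold higher number from compound 2 to compound 4 (0.10 log units; within the scatter) lies within the scatter, so isopropoxy in place of methoxycarbonyl shows no separate change here.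

As far as these compounds go, whether a longer plain alkyl chain would read like the branched groups or like the oxygen-bearing chains stays open, as does the reading for an amine or a carboxylic acid at the end of the chain. Nothing available gives a reason for these steps.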